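This account rests on a few compounds, and the source may have more. Where it says the series, first, only, none or still open, it means among the compounds named here.

In a functional assay on J774 cells (Mus musculus) for cytotoxicity, read by resazurin assay, with a stated time of 72 h (a higher number here means a weaker inhibitor, a lower number a stronger inhibitor), the three measured compounds give these numbers:

Compound 1 `O=S(=O)(Nc1cccc(CO)c1)c1ccc(-c2ccccc2)cc1` gives 2200 nM.
Compound 2 `O=S(=O)(Nc1ccc(CO)c(CO)c1)c1ccc(-c2ccc(F)cc2)cc1` gives 1000 nM.
Compound 3 `O=S(=O)(Nc1cccc(CO)c1)c1ccc(-c2ccc(C(F)(F)F)cc2)cc1` gives 2500 nM.

Compound 3 thus has the highest of the three numbers; compound 1 lies nearest, within the scatter, and compound 2 furthest, beyond it. Compound 4 `O=S(=O)(Nc1cccc(CO)c1)c1ccc(-c2ccc(F)cc2)cc1` differs from compound 3 by fluoro in place of trifluoromethyl on an aromatic carbon. Among the measured compounds shown here, the one step that bears on this place is a 1.1-fold higher number from compound 1 to compound 3 (0.06 log units; within the scatter), which shows that trading hydrogen for trifluoromethyl there barely moved the number. Compound 2 also carries a fluoro at that place, but it differs from compound 3 in more than one spot, so its lower value cannot be assigned to the fluoro alone. The step is therefore expected to be small, a 1.3-fold lower number from compound 3 to compound 4 (0.10 log units; within the scatter). Compound 4 is estimated at 2000 nM, within 1000 nM to 4000 nM.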

Compound 4, half-maximal inhibitory concentration: 3500 nM
Compound 4: the middle estimate sits 1.8-fold (0.24 log units) below what was measured; the measured number falls inside the stated range.
By their numbers in this assay, from the lowest: compound 2; then compounds 1, 3 and 4 (each within the scatter of the next).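

In this assay, fluoro at this aromatic carbon reads like both neighbours in the series, trifluoromethyl (a 1.4-fold higher number from compound 3 to compound 4 (0.15 log units; within the scatter)) and hydrogen (a 1.6-fold higher number from compound 1 to compound 4 (0.20 log units; within the scatter)), so the three groups are not separated here. The lower number of compound 2 now traces to its extra hydroxymethyl rather than to the fluoro (a 3.5-fold higher number from compound 2 to compound 4 (0.54 log units; beyond the scatter)). No measurement at hand explains either finding.

Going by these compounds, whether an amine or a carboxylic acid at this aromatic carbon would also leave the number unchanged stays open. So does whether the extra hydroxymethyl would lower the number with hydrogen or trifluoromethyl at that carbon.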